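This account rests on a few compounds, and the source may have more. Where it says the series, first, only, none or still open, it means among the compounds named here.

Compound 1 `ClCc1ccccc1Cn1cnc2c(Cl)nc(Cl)nc21`: 810 nM
Compound 2 `ClCc1ccccc1Cn1cnc2c(Cl)ncnc21`: 11000 nM
Compound 3 `ClCc1cccc(Cn2cnc3ncnc(Cl)c32)c1`: 1580 nM

In a functional assay on MCF7 cells (Homo sapiens) for cytotoxicity, read by sulforhodamine B assay, with a stated time of 48 h (on this read-out lower numbers stand for stronger inhibition of growth and higher numbers for weaker inhibition of growth), compound 2 gives 11000 nM, the highest of the three numbers, so among these compounds it is the weakest inhibitor of growth. Its nearest neighbour is compound 3, which gives 1580 nM; compound 1 gives 810 nM and stands furthest away.

Compound 4 `Nc1nc(Cl)c2ncn(Cc3ccccc3CCl)c2n1` has not yet been measured. It differs from compound 2 in one place: amino in place of hydrogen on an aromatic carbon. The new group sits on an aromatic carbon of the six-membered ring with two nitrogens, between two ring nitrogen atoms and meta to the chloro group.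

For the measured compounds named here, only one measured step concerns a single change on this ring: a 14-fold higher number from compound 1 to compound 2 (1.13 log units; beyond the scatter). There a chloro was swapped for hydrogen at another carbon and this assay moved a long way, which shows that the ring is sensitive to what is attached to it. Going by the values given here, no measured pair, however, shows what an amino group does at the new position, so the direction cannot be read from the data. The expectation is a moderate shift, more likely downward, with a wide range. Compound 4 is therefore expected to give 4000 nM, with a range of 1000 nM to 16000 nM, which amounts to an expected step of a 2.8-fold lower number from compound 2 to compound 4 (0.44 log units; beyond the scatter).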

Compound 4, concentration for 50% growth inhibition: 6030 nM
Compound 4: the middle estimate sits 1.5-fold (0.18 log units) below what was measured; low and high end bracket the measured number.
By their numbers in this assay, from the lowest: compounds 1 and 3 (each within the scatter of the next); then compounds 4 and 2 (each within the scatter of the next).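

In this assay, an amino group on the aromatic carbon between two ring nitrogen atoms gives a 1.8-fold lower number from compound 2 to compound 4 (0.26 log units; within the scatter) and so cannot be told apart from the hydrogen it replaces. The same carbon carries chloro in compound 1, and the change to amino there gives a 7.4-fold higher number from compound 1 to compound 4 (0.87 log units; beyond the scatter), a step that goes the same way as the earlier 14-fold higher number from compound 1 to compound 2 (1.13 log units; beyond the scatter) and is also beyond the scatter. Of the three groups seen at this carbon, only chloro stands apart, while amino and hydrogen give numbers within the scatter of each other, and nothing available here explains why.

As far as these compounds go, it remains open whether other groups at this carbon, such as bromo, methyl or methoxy, would group with chloro or with amino and hydrogen. From the compounds shown here alone, it also remains open whether amino would leave the number just as unmoved in a compound with the chloromethyl group placed as in compound 3, or with the other chloro of the shared core replaced by an amine.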